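This account rests on a few compounds, and the source may have more. Where it says the series, first, only, none or still open, it means among the compounds named here.

Compound 1 `CCC(C(=O)N1CCN(c2cccc(C(F)(F)F)c2)CC1)N1C(=O)CC(C)C1=O`: 75.1 mg/kg
Compound 2 `Cc1cccc(N2CCN(C(=O)C(C)N3C(=O)CC(C)C3=O)CC2)c1`: 122 mg/kg

Both were tested in a functional assay on the whole organism (strain Swiss) with Mus musculus as the target, in the maximal electroshock model, with a stated time of 0.25 h; a higher number here means that more compound is needed for the effect, a lower number that less compound is needed. Compound 1 gives 75.1 mg/kg, and compound 2 gives 122 mg/kg; the gap between the two lies within the usual scatter, so compound 1 sits at the low end of the pair without any real separation from compound 2. Compound 3 `CCC(C(=O)N1CCN(c2cccc(Cl)c2)CC1)N1C(=O)CC(C)C1=O` has not yet been measured. It differs from compound 1 in one place: chloro in place of trifluoromethyl on an aromatic carbon. Among the compounds with values here, no measured pair shows this change, so no step beyond the scatter is expected in this assay in either direction. Compound 3 is expected to give 80 mg/kg, between 40 mg/kg and 160 mg/kg, a step of a 1.1-fold higher number from compound 1 to compound 3 (0.03 log units; within the scatter).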

Compound 3, dose for half-maximal effect: 117 mg/kg
For compound 3 the middle estimate is 1.5-fold (0.17 log units) below the measured one, within the range that was stated.
By their numbers in this assay, from the lowest: compounds 1, 3 and 2 (each within the scatter of the next).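

In this assay, chloro in place of trifluoromethyl on this aromatic carbon gives a 1.6-fold higher number from compound 1 to compound 3 (0.19 log units; within the scatter) so one heavy atom here serves as well as four within what this assay can separate. Within the data shown here, this is the first single-place comparison, and it shows no real separation at this position. Nothing available accounts for the result.

The compounds shown leave open whether fluoro, methoxy, nitrile or an amine at this place would also stay within the scatter of compound 1.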